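Acetyl in Place of Oxazolylcarbonyl: Expected Cytotoxicity

The compounds below may be only part of what the source reports. "The series", "measured", "known", "first", "only" and "open" are said of these compounds alone.

Compound 3 `COc1ccc(-c2cnc(NC(=O)c3cnco3)n2C)cc1` was tested in a toxicity assay on THP-1 cells (Homo sapiens) for inhibition; on this read-out higher numbers stand for lower toxicity in this test and lower numbers for higher toxicity in this test. In this assay compound 3 gives only the limit > 100000 nM, not a number. Its neighbours stand the same way. In this assay compound 1 `COc1ccc(-c2cnc(NC(=O)c3cccnc3)n2C)cc1` gives the limit > 100000 nM. In this assay compound 2 `COc1ccc(-c2cnc(NC(=O)c3ccco3)n2C)cc1` gives the limit > 100000 nM. The steps a step that the two limits leave unreadable from compound 1 to compound 3 and a step that the two limits leave unreadable from compound 2 to compound 3 cannot be read, because all three values sit at the limit of > 100000 nM in this assay, at which 3 of the 3 values shown sit. For the measured compounds named here, compound 4 `COc1ccc(-c2cnc(NC(C)=O)n2C)cc1` is not yet measured. methyl in place of 1,3-oxazol-5-yl on a carbonyl carbon No measured step gives a size, so no step beyond the scatter is expected, and the estimated step that the limit leaves unreadable from compound 3 to compound 4 is expected to leave compound 4 at the limit. Compound 4 is expected to give 150000 nM in this assay, between 60000 nM and 400000 nM.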

Compound 4, half-maximal cytotoxic concentration: > 100000 nM
Compound 4: a limit, no number; the forecaster's own chance of this, stated with the estimate: 85%; the middle value lies beyond the limit too.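

In this assay compound 4 gives the limit > 100000 nM and not a number. Its steps from compound 1, compound 2 and compound 3 cannot be read, because all four compounds stand at one limit: the limit of > 100000 nM in this assay, at which 4 of the 4 values shown sit. The compounds shown leave open whether any of these groups on the carbonyl carbon changes the cytotoxic concentration.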